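Methylsulfanyl gives way to a larger selenium group

The source may report more compounds than this note shows. Statements on the series, on what has been measured and on what is new or still open speak of the compounds shown alone.

Compound 2, `CS/C(=N\C(=O)c1cc2ccccc2s1)NC(=O)c1cc2ccccc2s1`, gives 15800 nM in a functional assay on HepG2 cells (Homo sapiens) for cytotoxicity, read by MTT assay, with a stated time of 72 h; a lower number here means a stronger inhibitor of growth, a higher number a weaker inhibitor of growth. Among the measured compounds shown here, that is the highest of the two numbers measured so far; its nearest neighbour is compound 1, `C[Se]/C(=N\C(=O)c1cc2ccccc2s1)NC(=O)c1cc2ccccc2s1`, which in this assay gives 9590 nM, and the step of a 1.6-fold higher number from compound 1 to compound 2 (0.22 log units; within the scatter) stays within the scatter. Compound 3, `O=C(/N=C(/NC(=O)c1cc2ccccc2s1)[Se]Cc1ccccc1)c1cc2ccccc2s1`, has not yet been measured. It differs from compound 2 in one place: a group of 8 heavy atoms (7 carbon, 1 selenium; one six-membered aromatic ring of carbon only) in place of a group of 2 heavy atoms (1 carbon, 1 sulfur; no ring), on a carbon with a double bond to nitrogen. For the measured compounds named here, the only measured step that bears on this change is a 1.6-fold higher number from compound 1 to compound 2 (0.22 log units; within the scatter), which exchanged the same two chalcogens on the same carbon and turned out small. Nothing measured speaks to the larger group with its six-membered aromatic ring of carbon only, so that part of the change carries no guidance from the data. Compound 3 is therefore expected to sit near compound 2, perhaps with a somewhat lower number in the direction of compound 1, a step of a 2.0-fold lower number from compound 2 to compound 3 (0.30 log units; within the scatter) that would not exceed the scatter. Compound 3 is estimated at 8000 nM in this assay, with a range from 2500 nM to 25000 nM.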

Compound 3, concentration for 50% growth inhibition: 21000 nM
Beside the measured number, compound 3's estimate is 2.6-fold (0.42 log units) below it; the measured number falls inside the stated range.
By their numbers in this assay, from the lowest: compounds 1, 2 and 3 (each within the scatter of the next, the first and the last beyond it).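

In this assay, the carbon with a double bond to nitrogen, whose other neighbours are two amide-type nitrogens, now carries a group with a six-membered aromatic ring of carbon only, and a 1.3-fold higher number from compound 2 to compound 3 (0.12 log units; within the scatter) shows that this larger selenium group stays within the scatter of methylsulfanyl. The pair that keeps selenium in both compounds gives a sharper reading: phenyl in place of hydrogen on a saturated chain carbon bound to a selenium atom yields a 2.2-fold higher number from compound 1 to compound 3 (0.34 log units; beyond the scatter), the first step in this series beyond the scatter, modest in size and towards weaker inhibition of growth, so among these three compounds the added ring brings no gain. Nothing available explains this result.

The compounds shown leave open whether a benzyl group on sulfur would match compound 3 or whether the sulfur and selenium pair would again stay within the scatter with the ring present. They also leave open how an ethyl or longer chain on selenium would compare, and what an amine or a carboxylic acid on the phenyl ring would do to the number.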